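A few compounds are considered here, and "the series" means these few. Any claim that something is new, unique, unknown or untested is made for them only; others in the source may bear on it.

Working notes on the series. The shared core carries a chain from the aromatic nitrogen ending in an amine. Compound 1 `CN1CCN(CCCCCCn2c3c(c4ccccc42)C(=O)c2c[n+]([O-])c4ccccc4c2C3=O)CC1` gives 400 nM in a functional assay on MCF7 cells (Homo sapiens) for cytotoxicity, read by MTT assay, with a stated time of 72 h; on this read-out higher numbers stand for weaker inhibition and lower numbers for stronger inhibition. Compound 2 `CN1CCN(CCCCCn2c3c(c4ccccc42)C(=O)c2c[n+]([O-])c4ccccc4c2C3=O)CC1` gives 1260 nM in this assay. Compound 3 `CN1CCN(CCCCn2c3c(c4ccccc42)C(=O)c2c[n+]([O-])c4ccccc4c2C3=O)CC1` gives 100 nM in this assay. Compound 2 has the highest number of the three; the two steps that place it are a 3.2-fold higher number from compound 1 to compound 2 (0.50 log units; beyond the scatter) and a 13-fold lower number from compound 2 to compound 3 (1.10 log units; beyond the scatter).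

Compound 4 `O=C1c2c[n+]([O-])c3ccccc3c2C(=O)c2c1c1ccccc1n2CCN1CCCCC1` is not yet measured. The change from compound 2 is piperidin-1-yl in place of 3-(4-methylpiperazin-1-yl)propyl on a saturated chain carbon, two bonds along the chain from an aromatic nitrogen. The relevant steps are the chain-shortening ones: a 3.2-fold higher number from compound 1 to compound 2 (0.50 log units; beyond the scatter) and a 13-fold lower number from compound 2 to compound 3 (1.10 log units; beyond the scatter), which do not run in one direction, but the shorter chain of compound 3 gave the lowest number. Going by the values given here, a shorter chain with a different amine has no direct precedent here, so the expected step of a 4.2-fold lower number from compound 2 to compound 4 (0.62 log units; beyond the scatter) is toward a lower number but uncertain. Compound 4 is estimated at 300 nM, with a range of 60 nM to 1500 nM.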

Compound 4, half-maximal inhibitory concentration: 620 nM
Beside the measured number, compound 4's estimate is 2.1-fold (0.32 log units) below it; low and high end bracket the measured number.
By their numbers in this assay, from the lowest: compound 3; then compounds 1 and 4 (each within the scatter of the next); then compound 2.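

Placing piperidin-1-yl on a saturated chain carbon, two bonds along the chain from an aromatic nitrogen, gives in this assay a 2.0-fold lower number from compound 2 to compound 4 (0.31 log units; beyond the scatter) and a 6.2-fold higher number from compound 3 to compound 4 (0.79 log units; beyond the scatter), while a 1.6-fold higher number from compound 1 to compound 4 (0.19 log units; within the scatter) stays within the scatter. The 2-(piperidin-1-yl)ethyl chain therefore does not reach the low number of compound 3, so compound 4 goes against any reading that a shorter chain alone lowers the number, although chain length and terminal amine change together in this step and cannot be separated here. Nothing available bears on the reason for these differences.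

The compounds shown leave open how a 2-(4-methylpiperazin-1-yl)ethyl chain or a 4-(piperidin-1-yl)butyl chain would read, and either would separate the amine from the chain length. They also leave open how a morpholine ring at the chain end would compare.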